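Adding a Methoxy Group to Compound 3

This account rests on a few compounds, and the source may have more. Where it says the series, first, only, none or still open, it means among the compounds named here.

Compound 1 `COc1ccc(N(C)c2nc(Cl)nc3c2ncn3Cc2cc(OC)cc(OC)c2)cc1` and compound 2 `COc1ccc(N(C)c2nc(Cl)nc3c2ncn3Cc2cc(OC)c(OC)c(OC)c2)cc1` share one core, while compound 3 `COc1cc(Cn2cnc3c(Cl)nc(Cl)nc32)cc(OC)c1` and compound 4 `COc1cc(Cn2cnc3c(Cl)nc(Cl)nc32)cc(OC)c1OC` share another. The two cores differ by chloro in place of (4-methoxyphenyl)(methyl)amino on an aromatic carbon, and in a functional assay on AGS cells (Homo sapiens) for antiproliferative activity, read by MTT assay, with a stated time of 48 h (on this read-out lower numbers stand for stronger inhibition of growth and higher numbers for weaker inhibition of growth), this difference gave an 18-fold lower number from compound 1 to compound 3 (1.26 log units; beyond the scatter), with compound 1 at 69000 nM and compound 3 at 3800 nM. Within the first core, the change methoxy in place of hydrogen on an aromatic carbon gave a 1.2-fold higher number from compound 1 to compound 2 (0.09 log units; within the scatter), and compound 2 gives 85000 nM. Compound 4 carries the same change relative to compound 3, namely (methoxy in place of hydrogen on an aromatic carbon). Compound 4 is therefore expected to show roughly a 1.2-fold higher number from compound 3 to compound 4 (0.07 log units; within the scatter), because the same change gave a 1.2-fold higher number from compound 1 to compound 2 (0.09 log units; within the scatter). For compound 4 the expected value in this assay is 4500 nM, with a likely range from 2000 nM to 10000 nM.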

Compound 4, concentration for 50% growth inhibition: 9400 nM
For compound 4 the middle estimate is 2.1-fold (0.32 log units) below the measured one, and the stated range covers the measured number.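

In this assay, the added methoxy group gave a 2.5-fold higher number from compound 3 to compound 4 (0.39 log units; beyond the scatter), and this step does not differ meaningfully from the one on the other core: the same change on two cores in this assay, a 1.2-fold higher number (0.09 log units; within the scatter) from compound 1 to compound 2 and a 2.5-fold higher number (0.39 log units; beyond the scatter) from compound 3 to compound 4, 2.0-fold (0.30 log units) apart, within the scatter of two such steps. Exchanging (4-methoxyphenyl)(methyl)amino for chloro in the compounds with the extra methoxy gave a 9.0-fold lower number from compound 2 to compound 4 (0.96 log units; beyond the scatter), which also agrees with the earlier result: the same change on two cores in this assay, an 18-fold lower number (1.26 log units; beyond the scatter) from compound 1 to compound 3 and a 9.0-fold lower number (0.96 log units; beyond the scatter) from compound 2 to compound 4, 2.0-fold (0.30 log units) apart, within the scatter of two such steps. Within the data shown here, both changes therefore carried over between these two cores within the scatter, but with only one pair of steps per change, this does not show that they would carry over to any other core.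

On these data alone, it remains open whether a different group at the same place, such as ethoxy, hydroxyl or an amine, would give a similar step. The compounds shown also do not explain why either change has the size it does.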